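The source may report more compounds than this note shows. Statements on the series, on what has been measured and on what is new or still open speak of the compounds shown alone.

Working notes on the series.

Compound 3 `COc1cccc(CNCCCNc2ccnc3cc(CC4CCCCC4)ccc23)c1O` stands level with compound 1 `COc1ccc(F)cc1CNCCCNc1ccnc2cc(Cc3cc(C)cc(C)c3)ccc12` in a physicochemical assay for acid dissociation: compound 3 gives 9.47 and compound 1 gives 9.47, no change at the digits shown, and together the two are the highest of the three numbers at hand. Among the compounds with values here, compound 2 `COc1cccc(Oc2ccc3c(NCCCNCc4cccc(OC)c4O)ccnc3c2)c1` gives 9.28 in this assay, and the one counted step, a number 0.19 log units higher from compound 2 to compound 3 (within the scatter), keeps the whole spread within the scatter.

Compound 4 `COc1cccc(CNCCCNc2ccnc3cc(Cc4cc(C)cc(C)c4)ccc23)c1O` is compound 3 with one change at the group carried by the shared core: 3,5-dimethylphenyl in place of cyclohexyl on a saturated chain carbon bound to an aromatic carbon. Within the data shown here, the only measured step touching that same part of the core is a number 0.19 log units higher from compound 2 to compound 3 (within the scatter), which was within the scatter; compound 1, carrying the 3,5-dimethylbenzyl group that enters here, also sits level with compound 3. Among the measured compounds shown here, no measured step speaks directly to an aromatic ring replacing a saturated ring on the chain carbon, so no shift beyond the scatter is expected in this assay, and the step is estimated as no change at the digits printed from compound 3 to compound 4 (within the scatter). Compound 4 is therefore expected at 9.47, within 9.2 to 9.75.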

Compound 4, acid dissociation constant: 9.47
For compound 4 middle estimate and measured number coincide at the digits printed; low and high end bracket the measured number.
By their numbers in this assay, from the lowest: compounds 2, 1, 3 and 4 (each within the scatter of the next).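

In this assay, within the data shown here, 3,5-dimethylphenyl in place of cyclohexyl on a saturated chain carbon bound to an aromatic carbon gives no change at the digits printed from compound 3 to compound 4 (within the scatter) as the first direct reading of an aromatic ring replacing a saturated ring at this place. With 3,5-dimethylbenzyl in place of 3-methoxyphenoxy on an aromatic carbon, the reading is a number 0.19 log units higher from compound 2 to compound 4 (within the scatter) and so the three groups compared on the shared core remain within the scatter. The other end of the molecule behaves alike, since 2-hydroxy-3-methoxyphenyl in place of 5-fluoro-2-methoxyphenyl on a saturated chain carbon bound to an amine nitrogen gives no change at the digits printed from compound 1 to compound 4 (within the scatter) in the same assay.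

Going by these compounds, whether an amine or a carboxylic acid on the group carried by the shared core, or a longer chain linking the two amine nitrogens, would move this number stays open. No supporting data bear on the reason for these readings.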